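Swapping the benzyl group of compound 1

The compounds below may be only part of what the source reports. "The series", "measured", "known", "first", "only" and "open" are said of these compounds alone.

Results so far in a functional assay on HL-60 cells (Homo sapiens) for inhibition, read by CCK-8 assay, with a stated time of 48 h, tested at 20 uM (a lower number here means less inhibition of growth, a higher number more inhibition of growth at the concentration tested), are:
- compound 1 `COc1ccc(Cc2nnc(NC(=O)/C(C#N)=C/c3ccccc3OS(=O)(=O)c3ccc(C)cc3)s2)cc1` gives 25%
- compound 2 `COc1ccc(Cc2nnc(NC(=O)/C(C#N)=C/c3ccccc3OS(=O)(=O)c3ccc([N+](=O)[O-])cc3)s2)cc1` gives 51%
- compound 3 `COc1ccc(Cc2nnc(NC(=O)/C(C#N)=C/c3ccccc3OS(=O)(=O)c3ccccc3[N+](=O)[O-])s2)cc1` gives 25%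

Compound 1 sits level with compound 3, and both lie under compound 2. The next compound, compound 4 `Cc1ccc(S(=O)(=O)Oc2ccccc2/C=C(\C#N)C(=O)Nc2nnc(Cc3cccc(F)c3)s2)cc1`, keeps the core of compound 1 and changes one group: 3-fluorophenyl in place of 4-methoxyphenyl on a saturated chain carbon bound to an aromatic carbon. In words, this is 3-fluorophenyl in place of 4-methoxyphenyl on a saturated chain carbon bound to an aromatic carbon, or 4-methoxybenzyl to 3-fluorobenzyl.

Within the data shown here, no measured step touches this place. All three alter the aryl group on the sulfonyl sulfur, so they bear on it only indirectly. Two were modest, a number 26 percentage points higher from compound 1 to compound 2 (beyond the scatter) and a number 26 percentage points lower from compound 2 to compound 3 (beyond the scatter), and one was nil, no change at the digits printed from compound 1 to compound 3 (within the scatter). These steps suggest how far one change can move the result, but they give no direction for this one, so no step beyond the scatter is expected. The estimate is a number 3 percentage points higher from compound 1 to compound 4 (within the scatter), with a wide margin. For compound 4 the estimated value is 28% (expected range 10% to 52%).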

Compound 4, percent growth inhibition at one concentration: 11%
Beside the measured number, compound 4's estimate is 17 percentage points above it; measured number inside the range.
By their numbers in this assay, from the lowest: compound 4; then compounds 1 and 3 (each within the scatter of the next); then compound 2.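

Among these compounds, this position was untouched by the earlier steps, and it proves able to move the result: in this assay, the swap to 3-fluorobenzyl gives a number 14 percentage points lower from compound 1 to compound 4 (beyond the scatter) and so shows that growth inhibition at the tested concentration depends on this benzyl group as well as on the aryl group on the sulfonyl sulfur. The 4-methoxyphenyl group of compound 1 therefore reads better here than the 3-fluorophenyl group of compound 4. Nothing available explains this difference.

This single swap changes both the substituent and its place on the ring, so a 4-fluorophenyl or 3-methoxyphenyl group would be needed to separate the two. Also open, as far as these compounds go, is how an aminophenyl group or a longer chain between the ring and the core would read.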